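The compounds below may be only part of what the source reports. "The series", "measured", "known", "first", "only" and "open" are said of these compounds alone.

The study concerns three measured glycosylated triazole compounds and a fourth one still to be measured. Compound 1 `CC(=O)OC[C@H]1O[C@@H](n2cc(Cn3cc(C(C)=O)c4ccccc43)nn2)[C@H](OC(C)=O)[C@@H](OC(C)=O)[C@@H]1OC(C)=O` was tested in an ADME assay on NIH3T3 cells (Homo sapiens) for cytotoxicity, read by sulforhodamine B assay, with a stated time of 48 h; a higher number here means a weaker inhibitor, a lower number a stronger inhibitor. In this assay compound 1 reaches only the limit of the assay, > 200000 nM. Compound 2 `CC(=O)OC[C@H]1O[C@@H](n2cc(Cn3cc(/C=C/C(=O)c4cccnc4)c4ccccc43)nn2)[C@H](OC(C)=O)[C@@H](OC(C)=O)[C@@H]1OC(C)=O` differs from compound 1 by a step that the two limits leave unreadable from compound 1 to compound 2. In this assay compound 2 likewise gives only a limit, > 200000 nM. Compound 3 `CC(=O)OC[C@H]1O[C@@H](n2cc(Cn3cc(/C=C4/C(=O)Nc5ccccc54)c4ccccc43)nn2)[C@H](OC(C)=O)[C@@H](OC(C)=O)[C@@H]1OC(C)=O` is reached by a step that the two limits leave unreadable from compound 1 to compound 3, and from compound 2 by a step that the two limits leave unreadable from compound 2 to compound 3. In this assay compound 3 also stands at a limit, > 200000 nM. Thus compound 3 stands nowhere apart from the others: all three values sit at the limit of > 200000 nM in this assay, at which 3 of the 3 values shown sit, and none of the three steps can be read for size or direction.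

Compound 4 `CC(=O)OC[C@H]1O[C@@H](n2cc(Cn3cc(/C=C4/C(=O)Nc5ccc(F)cc54)c4ccccc43)nn2)[C@H](OC(C)=O)[C@@H](OC(C)=O)[C@@H]1OC(C)=O` carries the change (fluoro in place of hydrogen on an aromatic carbon). Going by the values given here, no measured step concerns a fluoro in place of hydrogen, and the three steps that are known are unreadable, so there is no measured basis for a step of any size in this assay. The expectation therefore rests on the position of compound 3 alone, and the step expected from compound 3 to compound 4 is a step that the limit leaves unreadable from compound 3 to compound 4, no shift beyond the scatter. Compound 4 is estimated to give 250000 nM in this assay, within a range from 60000 nM to 1000000 nM, most likely again reported only as a limit.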

Compound 4, half-maximal inhibitory concentration: 62500 nM
For compound 4 the middle estimate is 4.0-fold (0.60 log units) above the measured one; the measured number falls inside the stated range.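

In this assay, going by these compounds alone, fluoro in place of hydrogen on an aromatic carbon, meta to a fused ring and para to a fused ring, gives an at least 3.2-fold lower number from compound 3 to compound 4 (0.50 log units; beyond the scatter), the first step that can be read for direction, since the steps among compound 1, compound 2 and compound 3 cannot be read. The larger exchanges on the aromatic carbon can now be read in the same direction, as an at least 3.2-fold lower number from compound 2 to compound 4 (0.50 log units; beyond the scatter) and as an at least 3.2-fold lower number from compound 1 to compound 4 (0.50 log units; beyond the scatter), and all three sizes are only minimum sizes, each starting from a compound that stands at a limit. Compound 4 is therefore the only compound of the four with a number rather than a limit: the limit of > 200000 nM in this assay, at which 3 of the 4 values shown sit.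

The compounds shown leave open whether chloro, methyl or methoxy on this same aromatic carbon would also lower the number, or whether fluoro on another carbon of that ring would do so. They also leave open how large the step from hydrogen to fluoro really is, and whether fluoro would lower the number with the acetyl group of compound 1 in place of the group that compound 4 carries.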